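Cytotoxicity notes: moving the bromine on compound 3

The source may hold more compounds than are shown below. What is called first, only, known or untested is meant among the compounds shown, and "the series" means these compounds.

Compound 1 `COc1ccc(-c2nnc(-c3nn(C)c4ccccc34)o2)cc1` in an ADME assay on L02 cells (Homo sapiens) for cytotoxicity, read by MTT assay, with a stated time of 72 h (on this read-out lower numbers stand for stronger inhibition and higher numbers for weaker inhibition), gives only a limit, > 100000 nM.
Compound 2 `Cn1nc(-c2nnc(-c3cccc(Cl)c3)o2)c2ccccc21` in this assay gives only a limit, > 100000 nM.
Compound 3 `Cn1nc(-c2nnc(-c3ccccc3Br)o2)c2ccccc21` in this assay gives 89000 nM.

For the measured compounds named here, compound 3 holds the only real number in the set; the other two values are limits, and two of the three results sit at the limit of > 100000 nM in this assay, at which 2 of the 3 values shown sit. Going by the values given here, the single measured step, an at least 1.1-fold lower number from compound 2 to compound 3 (0.05 log units; that floor lies within the scatter), lies within the usual scatter, so no direction can be read from it.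

Compound 4 `Cn1nc(-c2nnc(-c3cccc(Br)c3)o2)c2ccccc21` has the same atoms as compound 3 joined differently: 3-bromophenyl in place of 2-bromophenyl on an aromatic carbon. It carries a 3-bromophenyl where compound 2 carries a 3-chlorophenyl, and compound 2 reports only a limit. Among the compounds with values here, the only step measured bears on the halogen type and the group name at once and was too small to call, so nothing favours a large move.

The step of a 1.1-fold higher number from compound 3 to compound 4 (0.05 log units; within the scatter) is expected to be small and undirected, with a fair chance that compound 4 returns to the limit. Compound 4 is estimated at 100000 nM, within 40000 nM to 250000 nM.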

Compound 4, half-maximal inhibitory concentration: > 100000 nM
Compound 4 gave a limit, no number; the forecaster's own chance of this, stated with the estimate: 55%; the middle value lies on the limit itself.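

Swapping 2-bromophenyl for 3-bromophenyl on the same carbon of the five-membered ring gives an at least 1.1-fold higher number from compound 3 to compound 4 (0.05 log units; that floor lies within the scatter), so this first comparison of two bromine placements shows no readable dependence on placement in this assay, and the figure is a floor rather than a full size. For the compounds shown here, compound 4 gives only a limit, which leaves compound 3 as the only compound with a real number, and that number cannot be set apart from the 3-bromophenyl result by more than the scatter allows. The bromo-for-chloro step between the 3-substituted pair cannot be read with both ends at limits, so the halogen question raised by the earlier compounds gains nothing, and the series now crowds further at one end of the scale: the limit of > 100000 nM in this assay, at which 3 of the 4 values shown sit.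

As far as these compounds go, whether an amine or a carboxylic acid on the phenyl ring in place of the bromine would give a number clearly lower than these remains open, as does the result for 2-chlorophenyl. The compounds shown also leave open what a longer chain in place of the methyl on the shared core would do to the read-out.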